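A few compounds are considered here, and "the series" means these few. Any claim that something is new, unique, unknown or untested is made for them only; others in the source may bear on it.

Measured so far:
- compound 1 `COc1ncnc2c1c(-c1ccsc1)cn2[C@@H]1O[C@H](CO)[C@@H](O)[C@H]1O` gives 75300 nM in an ADME assay on MRC5 cells (Homo sapiens), read by MTT assay, with a stated time of 72 h; on this read-out lower numbers stand for stronger inhibition and higher numbers for weaker inhibition.
- compound 2 `CN(C)c1ncnc2c1c(-c1ccsc1)cn2[C@@H]1O[C@H](CO)[C@@H](O)[C@H]1O` gives only a limit of the assay, > 100000 nM, in this assay.

Compound 1 holds the only actual number shown in this assay; the other value is a limit and not a number. Among the measured compounds shown here, the one measured step, an at least 1.3-fold higher number from compound 1 to compound 2 (0.12 log units; that floor lies within the scatter), is a change in a different part of the molecule and its floor lies within the scatter, because the limit of > 100000 nM in this assay, at which 1 of the 2 values shown sits, means compound 2 sits at the edge of what the assay can report.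

Compound 3 `COc1ncnc2c1c(-c1ccccc1)cn2[C@@H]1O[C@H](CO)[C@@H](O)[C@H]1O` is not yet measured. It differs from compound 1 by phenyl in place of thiophen-3-yl on an aromatic carbon. No measured step touches this position, so nothing shown speaks for a shift in either direction, and compound 1 already sits close to the upper end of the assay range.

Compound 3 is therefore expected to give a value near that of compound 1, with the step of a 1.1-fold higher number from compound 1 to compound 3 (0.03 log units; within the scatter) staying within the scatter. Compound 3 is estimated at 80000 nM, with a range from 30000 nM to 150000 nM.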

Compound 3, half-maximal inhibitory concentration: > 100000 nM
Compound 3: only a limit was reported (the forecaster's own chance of this, stated with the estimate: 40%); middle value at least 1.2-fold (0.09 log units) from the limit.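

In this assay compound 3 gives only a limit of the assay, not a number. Phenyl in place of thiophen-3-yl is the first change shown on this aromatic carbon of the five-membered ring, and it gives an at least 1.3-fold higher number from compound 1 to compound 3 (0.12 log units; that floor lies within the scatter), so swapping a five-membered aromatic ring with sulfur for a six-membered ring of carbon only brings no stronger inhibition here. The swap may do little or may weaken inhibition well beyond the scatter, and the true size of the step cannot be read because of the ceiling on the read-out: the limit of > 100000 nM in this assay, at which 2 of the 3 values shown sit.

With only these two aromatic rings shown at this position, it remains open whether any group placed here could move the number clearly away from compound 1, which gives 75300 nM, in either direction. A small amine, a carboxylic acid or a longer alkyl chain in place of the thiophen-3-yl would test this, and only a compound with a real number rather than a limit could put a size on such a change.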